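Solubility notes: amide-side replacement on the shared core

The compounds below may be only part of what the source reports. "The series", "measured", "known", "first", "only" and "open" are said of these compounds alone.

Of the compounds shown here, two have been measured, one more awaits measurement. Compound 1 `CC(=O)Nc1nc(-c2cc(Cl)c(Cl)s2)cs1` and compound 2 `CC(=O)N[C@@H](C)C(=O)NC1=NN(c2ccc(Cl)c(Cl)c2)CC1` were run in a physicochemical assay for solubility, measured as kinetic solubility, with a stated time of 1 h, at pH 7.4; a lower number here means a less soluble compound, a higher number a more soluble compound. In this assay compound 1 gives 1000 nM; compound 2 gives 58000 nM, the higher of the two numbers and well beyond the scatter from compound 1. Among the compounds with values here, the two differ in more than one place, so no single-change step is available and the two values are noted only as they stand.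

Compound 3 `Cc1ncncc1C(=O)NC1=NN(c2ccc(Cl)c(Cl)c2)CC1` is built on the core of compound 2 with one change: 4-methylpyrimidin-5-yl in place of 1-acetamidoethyl on a carbonyl carbon. The 1-acetamidoethyl group that leaves carries one hydrogen-bond donor; the 4-methylpyrimidin-5-yl group that enters carries none and brings a six-membered aromatic ring. Within the data shown here, no measured pair in this set isolates such a change, so the expectation rests on compound 2 alone.

In this assay compound 3 is expected to give 20000 nM, with a range of 5000 nM to 60000 nM. The step of a 2.9-fold lower number from compound 2 to compound 3 (0.46 log units; beyond the scatter) is expected to be a modest decrease, near the edge of the scatter.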

Compound 3, solubility: 12000 nM
For compound 3 the middle estimate is 1.7-fold (0.22 log units) above the measured one; the range from low to high includes it.
By their numbers in this assay, from the lowest: compound 1; then compound 3; then compound 2.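

On the carbonyl carbon whose other neighbour is the amide-type nitrogen, the series now has its first single-place comparison: in this assay the change gives a 4.8-fold lower number from compound 2 to compound 3 (0.68 log units; beyond the scatter) and so registers beyond the scatter, though only modestly. Exchanging the ring-free 1-acetamidoethyl group, with its hydrogen-bond donor and defined stereocentre, for the six-membered aromatic 4-methylpyrimidin-5-yl group, with no donor, does not bring a large drop at this position, and compound 3 still gives 12000 nM in this comparison. No measured property bears on this step, and the number therefore stands as an observation without an assigned cause.

The single step changes the ring, the donor count and the stereocentre together, and the compounds shown do not separate these features from one another. Going by these compounds, it also stays open whether a plain phenyl ring, or a longer chain ending in a primary amine or a carboxylic acid, on this carbonyl carbon would give a number closer to that of compound 2 or to that of compound 3.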